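Adding a hydroxy group to the phenyl of compound 2

The source may report more compounds than this note shows. Statements on the series, on what has been measured and on what is new or still open speak of the compounds shown alone.

Values measured so far in a functional assay on MCF7 cells (Homo sapiens) for cytotoxicity, read by colorimetric assay and MTT assay (a lower number here means a stronger inhibitor, a higher number a weaker inhibitor), are as follows
- compound 1 `COc1ccc2cc(-c3ccccc3)c(O)nc2c1` gives 10000 nM
- compound 2 `COc1cc(OC)c2cc(-c3ccccc3)c(O)nc2c1` gives 10000 nM
- compound 3 `Cn1c(=O)c(-c2ccc(O)cc2)cc2c(O)cc(O)cc21` gives 10000 nM

Compound 2 (10000 nM) stands level with compound 1 and compound 3 on these numbers. The next compound, compound 4 `COc1cc(OC)c2cc(-c3ccc(O)cc3)c(O)nc2c1`, differs from compound 2 by one change, phenyl to 4-hydroxyphenyl, with hydroxy in place of hydrogen on an aromatic carbon.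

For the measured compounds named here, no measured step shows this change directly. Going by the values given here, the only measured step, no change at the digits printed from compound 1 to compound 2 (within the scatter), is a methoxy in place of hydrogen on an aromatic carbon, so it bears on the new step only loosely. Compound 3, which also carries a 4-hydroxyphenyl group on a differently substituted core, gives 10000 nM and sits level with compound 2. On this evidence, no step beyond the scatter is expected in this assay, in either direction. The expected step is no change at the digits printed from compound 2 to compound 4 (within the scatter). Compound 4 is estimated at 10000 nM (expected range 3000 nM to 20000 nM).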

Compound 4, half-maximal inhibitory concentration: 10000 nM
The estimate for compound 4 equals the measured number at the digits printed; the measured number falls inside the stated range.
By their numbers in this assay, from the lowest: compounds 1, 2, 3 and 4 (each within the scatter of the next).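

In this assay, phenyl to 4-hydroxyphenyl, with hydroxy on an aromatic carbon para to a large group, gives no change at the digits printed from compound 2 to compound 4 (within the scatter). For the compounds shown here, this is a direct reading of the change on a single core: the earlier compounds showed 4-hydroxyphenyl only in compound 3, which differs from compound 2 in more than one place and so could not isolate this group. No line of measured data accounts for the result.

As far as these compounds go, whether an amine, a carboxylic acid or a longer alkoxy chain in place of this hydroxy would give a different value remains open. The compounds shown all stand level, and they leave open which changes to this ring or to the methoxy groups of the shared core, if any, would move the value in this assay.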